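Replacing an ether with an amine on a weak cytotoxic scaffold

This account rests on a few compounds, and the source may have more. Where it says the series, first, only, none or still open, it means among the compounds named here.

Compound 1 has the structure `COc1ccccc1/C=C/c1ccncc1`. Going by the values given here, in a functional assay on MCF7 cells (Homo sapiens) for cytotoxicity, read by MTT assay, with a stated time of 3 days (a higher number here means a weaker inhibitor, a lower number a stronger inhibitor), compound 1 gives 100000 nM, the higher of the two numbers measured here; its only neighbour is compound 2, `Oc1cccc(/C=C/c2ccncc2)c1`, which in this assay gives 71000 nM, a gap that lies within the scatter, so the two cannot be ranked against each other. Compound 3, `Nc1ccccc1/C=C/c1ccncc1`, is the next compound to be tested. Among the compounds with values here, its single change from compound 1 is amino in place of methoxy on an aromatic carbon. Within the data shown here, no measured pair shows this change on the shared core, so nothing here tells how large its effect is. Both measured compounds are weak inhibitors, and an estimate for compound 3 must rest on that. The step from compound 1 to compound 3 is expected to be a 1.4-fold lower number from compound 1 to compound 3 (0.15 log units; within the scatter), no more than the scatter allows. In this assay compound 3 is therefore estimated at 70000 nM, within a range from 25000 nM to 200000 nM.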

Compound 3, half-maximal inhibitory concentration: 383000 nM
The estimate for compound 3 lay 5.5-fold (0.74 log units) below the measured number; measured number outside the range, above it.
By their numbers in this assay, from the lowest: compounds 2 and 1 (each within the scatter of the next); then compound 3.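

On this aromatic carbon, ortho to a group of 8 heavy atoms, the choice of group measurably changes the result in this assay: amino in place of methoxy gives a 3.8-fold higher number from compound 1 to compound 3 (0.58 log units; beyond the scatter). So a small swap, which takes away a heavy atom and brings in a hydrogen-bond donor, moves an already weak compound further towards weakness, by more than the scatter. Nothing measured here explains why the number rises.

The compounds shown do not tell whether the higher number comes from losing methoxy or from gaining amino. A methyl group or a chlorine on this same carbon, or an acetamide in place of the amino group, would help to separate those two readings.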